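Two limits and a smaller group: what compound 3 may show

The source may report more compounds than this note shows. Statements on the series, on what has been measured and on what is new or still open speak of the compounds shown alone.

Measured compounds:
Compound 1 `CC(C)CC(c1c(O)cc(/C=C/c2ccc(O)c(O)c2)oc1=O)c1c(O)cc(/C=C/c2ccc(O)c(O)c2)oc1=O` in a functional assay on liver (Mus musculus), with a stated time of 1.5 h (a lower number here means a stronger inhibitor, a higher number a weaker inhibitor), gives > 200000 nM, which is a limit of the assay and not a number.
Compound 2 `CC(C)C(c1c(O)cc(/C=C/c2ccc(O)c(O)c2)oc1=O)c1c(O)cc(/C=C/c2ccc(O)c(O)c2)oc1=O` in this assay gives > 200000 nM, again a limit and not a number.

Compound 2 therefore stands only at the limit; no number marks its place, and the same holds for compound 1, as the limit of > 200000 nM in this assay, at which 2 of the 2 values shown sit, records. The step that the two limits leave unreadable from compound 1 to compound 2 cannot be read, since both ends sit at that limit. Compound 3 `CC(c1c(O)cc(/C=C/c2ccc(O)c(O)c2)oc1=O)c1c(O)cc(/C=C/c2ccc(O)c(O)c2)oc1=O` is not yet measured. It differs from compound 2 by methyl in place of isopropyl on a saturated chain carbon bound to two aromatic carbons. Among the compounds with values here, the one measured step bears on this change, as it also shortens the group on that same carbon, yet its size stays unknown. Nothing here points to a gain, so compound 3 is expected to give 200000 nM in this assay, within 80000 nM to 600000 nM. The expected step of a number no higher from compound 2 to compound 3 (the limit leaves the size open) is estimated to be none beyond the scatter, most likely another limit.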

Compound 3, half-maximal inhibitory concentration: > 200000 nM
Compound 3: a limit, no number; the forecaster's own chance of this, stated with the estimate: 80%; the middle value lies on the limit itself.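

Within the data shown here, no step among compound 1, compound 2 and compound 3 can be read, because each gives a limit of the assay and not a number: the limit of > 200000 nM in this assay, at which 3 of the 3 values shown sit. The compounds shown leave open whether any group on a saturated chain carbon bound to two aromatic carbons changes the result in this assay at all.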